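This account rests on a few compounds, and the source may have more. Where it says the series, first, only, none or still open, it means among the compounds named here.

Measured so far:
- compound 1 `COC(=O)C1=C(C)N=C(C)/C(=C(/O)OC)C1c1cccc(N/C(=N/CCNC2CCN(c3ccccc3)CC2)NC#N)c1`: in an assay on SK-N-MC cells for inhibition of Neuropeptide Y receptor type 1 (Homo sapiens) (a lower number here means a stronger inhibitor, a higher number a weaker inhibitor), compound 1 gives 10 nM
- compound 2 `COC(=O)C1=C(C)N=C(C)/C(=C(/O)OC)C1c1cccc(N/C(=N/CCNC2CCN(c3ccccc3[N+](=O)[O-])CC2)NC#N)c1`: compound 2 gives 4 nM
- compound 3 `COC(=O)C1=C(C)N=C(C)/C(=C(/O)OC)C1c1cccc(N/C(=N/CCNC2CCN(c3ccccc3OC)CC2)NC#N)c1`: compound 3 gives 4 nM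

Compound 1 has the highest number of the three. Both substitutions on the aromatic carbon lowered it: a 2.5-fold lower number from compound 1 to compound 2 (0.40 log units; beyond the scatter) and a 2.5-fold lower number from compound 1 to compound 3 (0.40 log units; beyond the scatter), whereas no change at the digits printed from compound 2 to compound 3 (within the scatter), so the two groups cannot be told apart.

Compound 4 `COC(=O)C1=C(C)N=C(C)/C(=C(/O)OC)C1c1cccc(N/C(=N/CCNC2CCN(c3ccccc3OC(F)(F)F)CC2)NC#N)c1` differs from compound 1 in one place: trifluoromethoxy in place of hydrogen on an aromatic carbon. The two steps from compound 1 to compound 2 and to compound 3 bear on this change; each was a modest lowering, and neither group mattered more than the other. A step of the same kind is therefore expected for compound 4, a 2.0-fold lower number from compound 1 to compound 4 (0.30 log units; within the scatter). The estimate for compound 4 is 5 nM, with a range from 2 nM to 12 nM.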

Compound 4, half-maximal inhibitory concentration: 28 nM
Estimate against measurement, compound 4: 5.6-fold (0.75 log units) below, and the stated range ends below it.
By their numbers in this assay, from the lowest: compounds 2 and 3 (each within the scatter of the next); then compound 1; then compound 4.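

In this assay, a group at this aromatic carbon, ortho to a large group, does not always lower the number: trifluoromethoxy in place of hydrogen gives a 2.8-fold higher number from compound 1 to compound 4 (0.45 log units; beyond the scatter) and so reverses the direction seen with nitro and methoxy. The oxygen alone does not secure the lower number, with trifluoromethyl in place of methyl giving a 7.0-fold higher number from compound 3 to compound 4 (0.85 log units; beyond the scatter) and trifluoromethoxy in place of nitro giving a 7.0-fold higher number from compound 2 to compound 4 (0.85 log units; beyond the scatter) as the matching step. Nothing available explains this reversal.

Open, as far as these compounds go, is whether an amine, a chlorine or an ethoxy group at this carbon would follow methoxy or trifluoromethoxy.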